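Trifluoromethoxy for Bromo on the Shared Core

The source may hold more compounds than are shown below. What is called first, only, known or untested is meant among the compounds shown, and "the series" means these compounds.

Three measured compounds share one core. Compound 1 `CCC(CC)(CC(=O)Nc1cccc(OCc2ccc3cc(F)ccc3n2)c1)C(=O)O` gives 2 nM in a functional assay on ileum (Cavia porcellus) for antagonist activity at cysteinyl leukotriene receptor (Homo sapiens); a higher number here means a weaker inhibitor, a lower number a stronger inhibitor; compound 2 `CCC(CC)(CC(=O)Nc1cccc(OCc2ccc3ccc(Br)cc3n2)c1)C(=O)O` gives 4 nM in this assay; compound 3 `CCC(CC)(CC(=O)Nc1cccc(OCc2ccc3cc(C)ccc3n2)c1)C(=O)O` gives 24 nM in this assay. Compound 2 holds the second highest number of the three, within the scatter of compound 1 and beyond the scatter from compound 3. Going by the values given here, the only single-point step measured, a 12-fold higher number from compound 1 to compound 3 (1.08 log units; beyond the scatter), concerns a different aromatic carbon, so it bears only loosely on compound 4 `CCC(CC)(CC(=O)Nc1cccc(OCc2ccc3ccc(OC(F)(F)F)cc3n2)c1)C(=O)O`, whose change is trifluoromethoxy in place of bromo on an aromatic carbon. That step shows a substituent swap on this core can move the number far. Compound 4 is expected to weaken modestly, a 2.0-fold higher number from compound 2 to compound 4 (0.30 log units; within the scatter), with an estimate of 8 nM and a range of 2 nM to 40 nM.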

Compound 4, half-maximal inhibitory concentration: 9 nM
The estimate for compound 4 lay 1.1-fold (0.05 log units) below the measured number; the measured number falls inside the stated range.
By their numbers in this assay, from the lowest: compounds 1 and 2 (each within the scatter of the next); then compound 4; then compound 3.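

Trifluoromethoxy in place of bromo gives a 2.3-fold higher number from compound 2 to compound 4 (0.35 log units; beyond the scatter) in this assay and is the only step shown at this aromatic carbon. Here 5 heavy atoms replace 1 and a hydrogen-bond acceptor enters, yet this step stays modest, though beyond the scatter, beside a 12-fold higher number from compound 1 to compound 3 (1.08 log units; beyond the scatter) on a different aromatic carbon. Nothing available explains the step. The compounds shown leave open how a methoxy group, a nitrile or an amine would read on this aromatic carbon. They also leave open whether fluoro, carried by compound 1 elsewhere on the shared core, would read the same here.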